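Para-aryl variation on the cinnamamide series

The compounds below may be only part of what the source reports. "The series", "measured", "known", "first", "only" and "open" are said of these compounds alone.

Three compounds of a shared core are measured in a functional assay on HEK293 cells for activation of melanin-concentrating hormone receptor 1 (Homo sapiens), read by inositol phosphate accumulation; on this read-out higher numbers stand for an effect only at larger amounts of compound and lower numbers for an effect already at smaller amounts. Compound 1 `CCCc1ccc(/C=C/C(=O)Nc2ccc3nc(CCC)cc(N)c3c2)cc1` gives 3600 nM; compound 2 `CCCc1cc(N)c2cc(NC(=O)/C=C/c3ccc(SC)cc3)ccc2n1` gives 71 nM; compound 3 `CCCc1cc(N)c2cc(NC(=O)/C=C/c3ccc(I)cc3)ccc2n1` gives 280 nM, second highest of the three numbers, with a 3.9-fold higher number from compound 2 to compound 3 (0.60 log units; beyond the scatter) and a 13-fold lower number from compound 1 to compound 3 (1.11 log units; beyond the scatter). Compound 4 `CCCc1cc(N)c2cc(NC(=O)/C=C/c3ccc(Cl)c(Cl)c3)ccc2n1` carries the change (3,4-dichlorophenyl in place of 4-iodophenyl on a double-bonded chain carbon bound to a double-bonded chain carbon). Within the data shown here, no measured step exchanges one halogen-bearing phenyl for another; the two steps that touch the same ring position, a 51-fold lower number from compound 1 to compound 2 (1.71 log units; beyond the scatter) and a 13-fold lower number from compound 1 to compound 3 (1.11 log units; beyond the scatter), both replace propyl and are large, whereas the halogen-to-methylsulfanyl step is modest. A small step is expected here, likely within the scatter: a 1.3-fold lower number from compound 3 to compound 4 (0.10 log units; within the scatter). Compound 4 is estimated at 220 nM, between 70 nM and 700 nM.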

Compound 4, half-maximal effective concentration: 990 nM
For compound 4 the middle estimate is 4.5-fold (0.65 log units) below the measured one, outside the stated range (above it).
By their numbers in this assay, from the lowest: compound 2; then compound 3; then compound 4; then compound 1.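

Two halogen-bearing phenyls do not read alike at this place in this assay, with a 3.5-fold higher number from compound 3 to compound 4 (0.55 log units; beyond the scatter), so carrying halogen does not alone set the number. 3,4-Dichlorophenyl stands well apart from 4-(methylsulfanyl)phenyl, with a 14-fold higher number from compound 2 to compound 4 (1.14 log units; beyond the scatter), yet still gives a lower number than 4-propylphenyl, with a 3.6-fold lower number from compound 1 to compound 4 (0.56 log units; beyond the scatter), placing it third of the four. Nothing available explains this order.

Open, on these data alone, is whether the step from compound 3 to compound 4 follows the change of halogen or the added chlorine, a question 4-chlorophenyl would address. Also open, as far as these compounds go, is how 4-methoxyphenyl would read at this place.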